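A few compounds are considered here, and "the series" means these few. Any claim that something is new, unique, unknown or untested is made for them only; others in the source may bear on it.

This piece follows one change to compound 2, shown as `C=CC1=C(C(=O)Nc2ccc(C)cc2)C(c2ccc(F)cc2)OC1`, and asks what it should do in a functional assay on HeLa cells (Homo sapiens) for cytotoxicity, read by MTT assay, with a stated time of 24 h; on this read-out lower numbers stand for stronger inhibition and higher numbers for weaker inhibition. In this assay compound 2 gives > 100000 nM, which is a limit of the assay rather than a measured number. The compounds around it sit the same way. Compound 1, `C=CC1=C(C(=O)NCCCCC)C(c2ccc(OC)cc2)OC1`, gives in this assay the value > 100000 nM, again a limit. Compound 3, `C=CC1=C(C(=O)Nc2ccc(OCC)cc2)C(c2ccc(F)cc2)OC1`, gives in this assay the value > 100000 nM, also a limit. The only measured step among these, a step that the two limits leave unreadable from compound 2 to compound 3, therefore has no readable size or direction, since two limits cannot be compared with one another.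

Compound 4 is `C=CC1=C(C(=O)NCc2ccccc2F)C(c2ccc(F)cc2)OC1`, and its change from compound 2 is 2-fluorobenzyl in place of 4-methylphenyl on an amide-type nitrogen. Among the measured compounds shown here, no measured step speaks to this change, and the shared core is otherwise untouched, so there is nothing to read a direction from. What the numbers do show is summed up in the limit of > 100000 nM in this assay, at which 3 of the 3 values shown sit.

Because the limit of > 100000 nM in this assay, at which 3 of the 3 values shown sit, places every value seen so far at the same limit, compound 4 is expected to behave alike. Compound 4 is estimated to give 150000 nM in this assay, with a likely range from 40000 nM to 600000 nM. The expected step that the limit leaves unreadable from compound 2 to compound 4 is meant as no movement the assay could resolve.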

Compound 4, half-maximal inhibitory concentration: > 100000 nM
Compound 4: no number, only a limit (the forecaster's own chance of this, stated with the estimate: 85%); the middle value does not contradict the limit.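

Compound 2 and compound 4 both give only a limit in this assay, and no step between them can be read: the limit of > 100000 nM in this assay, at which 4 of the 4 values shown sit.

The compounds shown leave open whether any change to the amide nitrogen group, or elsewhere on the shared core, would give a measurable number in this assay, and how large its effect would be.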